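A few compounds are considered here, and "the series" means these few. Any claim that something is new, unique, unknown or untested is made for them only; others in the source may bear on it.

Measured compounds:
compound 1 `CN1CCC[C@@H]1[C@H]1COc2ccc(O)cc2O1` — 3500 nM
compound 2 `CN1CCC[C@@H]1[C@@H]1COc2ccc(O)cc2O1` — 3000 nM
compound 3 `CN1CCC[C@H]1[C@@H]1COc2ccc(O)cc2O1` — 12 nM

In an assay on Cerebral cortex (strain Sprague-Dawley) for displacement of a labelled ligand from Neuronal acetylcholine receptor; alpha4/beta2 (Rattus norvegicus) (a higher number here means a weaker inhibitor, a lower number a stronger inhibitor), compound 2 gives 3000 nM, the second highest of the three numbers. Compound 1 lies nearest, with a 1.2-fold lower number from compound 1 to compound 2 (0.07 log units; within the scatter), and compound 3 lies furthest, with a 250-fold lower number from compound 2 to compound 3 (2.40 log units; beyond the scatter), which rests on (the fact that compounds 2 and 3 differ only in the configuration as drawn).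

Compound 4 `Oc1ccc2c(c1)O[C@H]([C@H]1CCCN1)CO2` is the next step: hydrogen in place of methyl on an amine nitrogen in a ring. None of the measured steps bears on this change, since each of them is a change of configuration only, as shown by the fact that compounds 1 and 2 differ only in the configuration as drawn, the fact that compounds 1 and 3 differ only in the configuration as drawn and (the fact that compounds 2 and 3 differ only in the configuration as drawn), and the configuration of compound 2 is kept in compound 4. With no guide, the account expects compound 4 to sit close to compound 2, with no change at the digits printed from compound 2 to compound 4 (within the scatter) as the estimated step. The estimate for compound 4 in this assay is 3000 nM, expected between 600 nM and 15000 nM.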

Compound 4, inhibition constant: 1300 nM
For compound 4 the middle estimate is 2.3-fold (0.36 log units) above the measured one; low and high end bracket the measured number.
By their numbers in this assay, from the lowest: compound 3; then compound 4; then compounds 2 and 1 (each within the scatter of the next).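

In this assay, hydrogen in place of methyl on the amine nitrogen in the ring gives a modest gain, a 2.3-fold lower number from compound 2 to compound 4 (0.36 log units; beyond the scatter), so this nitrogen responds to a change of group in the configuration of compound 2. Among these compounds, the earlier compounds varied configuration only, and this is the first step that reads a change at this position. No known fact accounts for the size of this step.

The compounds shown leave open whether the same replacement gives a similar step in the configuration of compound 3. They also leave open how an ethyl group or a longer chain on this nitrogen would compare.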